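The source may report more compounds than this note shows. Statements on the series, on what has been measured and on what is new or still open speak of the compounds shown alone.

Measured compounds:
compound 1 `C=CCSc1nncc2cnc(COC)n12` — 79000 nM
compound 2 `C=CCSc1nncc2cnc(-c3ccccc3)n12` — > 48000 nM

Among the compounds with values here, in a functional assay for inhibition, with Homo sapiens as the target (on this read-out lower numbers stand for stronger inhibition and higher numbers for weaker inhibition), compound 1 gives 79000 nM, the only number recorded here. Compound 2 reaches only (the limit of > 48000 nM in this assay, at which 1 of the 2 values shown sits), which is a limit of the assay and not a number. Within the data shown here, the one measured step, a step that the limit leaves unreadable from compound 1 to compound 2, is therefore unreadable in size.

The compound to be measured is compound 3 `COCc1ncc2cnnc(O)n12`. It differs from compound 1 in one place: hydroxy in place of allylsulfanyl on an aromatic carbon. Among the measured compounds shown here, no measured step touches this position or this pair of groups, so nothing recorded here bears directly on the change. For the measured compounds named here, what the data show is only that compound 1 sits at a weak value and that its one neighbour, compound 2, lies at the limit.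

With compound 1 standing at 79000 nM, a small number of inhibition is not expected for compound 3; the step of a 1.4-fold higher number from compound 1 to compound 3 (0.14 log units; within the scatter) is estimated to run toward weaker inhibition or to lie within the scatter. Compound 3 is thus expected to give about 110000 nM, within 30000 nM to 400000 nM, with a fair chance that this assay again reports only a limit.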

Compound 3, half-maximal inhibitory concentration: > 48000 nM
Compound 3: no number, only a limit; the forecaster's own chance of this, stated with the estimate: 60%; the middle value lies beyond the limit too.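

In this assay, within the data shown here, compound 3 gives > 48000 nM as a limit of the assay and not a number, so the comparison of compound 1 with compound 3 yields no step that can be read. The compounds shown leave open how far, and in which direction, hydroxy in place of allylsulfanyl changes inhibition.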